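Swapping a methyl for fluoro on the aniline ring

This account rests on a few compounds, and the source may have more. Where it says the series, first, only, none or still open, it means among the compounds named here.

Measured so far:
compound 1, `Cc1ccc(Nc2cc(NC(=O)Nc3c(Cl)cccc3Cl)ncn2)cc1F`, 40.7%
compound 2, `COc1cc(NC(=O)Nc2cc(Nc3ccc(C)c(C)c3)ncn2)cc(OC)c1`, 45.3%
compound 3, `Cc1cc(F)cc(Nc2cc(NC(=O)Nc3c(Cl)cccc3Cl)ncn2)c1`, 78.1%

Of the compounds shown here, three sharing one core have been tested in a functional assay on NCI-H226 cells (Homo sapiens) for inhibition, read by MTT assay, with a stated time of 48 h, tested at 10 uM; a lower number here means less inhibition, a higher number more inhibition at the concentration tested (going by the name of the read-out). Compound 2 gives the second highest of the three numbers; its nearest neighbour is compound 1, whose value sits within the scatter of it, while compound 3 lies well beyond the scatter above it.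

Compound 4, `COc1cc(NC(=O)Nc2cc(Nc3ccc(C)c(F)c3)ncn2)cc(OC)c1`, has not been measured yet. It differs from compound 2 in one place: fluoro in place of methyl on an aromatic carbon. The new group sits on an aromatic carbon of a six-membered aromatic ring of carbon only, ortho to a methyl group and meta to a large group.

Going by the values given here, only one step between measured compounds is known, a number 37.4 percentage points higher from compound 1 to compound 3 (beyond the scatter), and it moves the fluoro and methyl around on the same ring rather than exchanging one for the other, so it does not bear directly on the change at hand. Compound 1, which carries the same 3-fluoro-4-methylphenyl group as compound 4 but a different urea partner, and compound 2 give values within the scatter of each other. A step within the scatter is therefore expected in this assay, with a number 2.3 percentage points lower from compound 2 to compound 4 (within the scatter) as the estimate; compound 4 is expected to give about 43%, somewhere between 25% and 62%.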

Compound 4, a percentage reported as inhibition, at one concentration (the size of the read-out at that concentration, not a potency): 39.7%
Compound 4: the middle estimate sits 3.3 percentage points above what was measured; low and high end bracket the measured number.
By their numbers in this assay, from the lowest: compounds 4, 1 and 2 (each within the scatter of the next); then compound 3.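

Read directly for the first time, fluoro in place of methyl on this aromatic carbon gives a number 5.6 percentage points lower from compound 2 to compound 4 (within the scatter) in this assay, so the assay does not separate the two groups at this position, with the urea partner shared by these two compounds. Going by these compounds alone, the only large step so far, a number 37.4 percentage points higher from compound 1 to compound 3 (beyond the scatter), belongs to a different kind of change: it moves the fluoro and methyl around the ring, with another urea partner, and exchanging one group for the other here shows nothing of that size. Nothing measured here speaks to what lies behind this result.

As far as these compounds go, whether a chloro, hydroxyl or amino group on the same carbon, or simply a hydrogen there, would also stay within the scatter of compound 2 remains open. Also open, from the compounds shown here alone, is whether fluoro in place of methyl would give a similarly small step with the urea partner of compound 1, or with the fluoro and methyl arranged as in compound 3.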